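A few compounds are considered here, and "the series" means these few. Any claim that something is new, unique, unknown or untested is made for them only; others in the source may bear on it.

Compound 1, `Cc1oncc1-c1cccc2c1CCC2c1ncc[nH]1`, gives > 10000 nM in a functional assay on CHO cells for agonist activity at Alpha-1B adrenergic receptor (Homo sapiens), read by FLIPR and calcium flux (on this read-out higher numbers stand for an effect only at larger amounts of compound and lower numbers for an effect already at smaller amounts), a limit of the assay.
Compound 2, `c1cc(-c2ncco2)c2c(c1)C(c1ncc[nH]1)CC2`, gives > 10000 nM in this assay, likewise a limit.

Both values sit at the limit of > 10000 nM in this assay, at which 2 of the 2 values shown sit, so the step that the two limits leave unreadable from compound 1 to compound 2 cannot be read. Compound 3, `c1cc(-c2nccs2)c2c(c1)C(c1ncc[nH]1)CC2`, differs from compound 2 by 1,3-thiazol-2-yl in place of 1,3-oxazol-2-yl on an aromatic carbon. For the measured compounds named here, the only measured step, from compound 1 to compound 2, is unreadable, so no step beyond the scatter is expected here. Compound 3 is therefore estimated at 15000 nM in this assay, within 4000 nM to 60000 nM, an expected step that the limit leaves unreadable from compound 2 to compound 3.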

Compound 3, half-maximal effective concentration: > 10000 nM
Compound 3 ended at the assay's limit (the forecaster's own chance of this, stated with the estimate: 85%); the middle value is on the limit's open side.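

The steps from compound 2 to compound 3 and from compound 1 to compound 3 cannot be read, since compound 3 also ends at a limit: the limit of > 10000 nM in this assay, at which 3 of the 3 values shown sit. The compounds shown leave open whether 1,3-thiazol-2-yl, 1,3-oxazol-2-yl and 5-methyl-1,2-oxazol-4-yl differ at all in this assay.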